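The source may report more compounds than this note shows. Statements on the series, on what has been measured and on what is new or still open speak of the compounds shown alone.

Series notes, sulfonamide set with a shared core.

Compound 1 `NC(=O)[C@@H](CCC(F)(F)F)N(CC12CC(c3ncon3)(C1)C2)S(=O)(=O)c1ccc(Cl)cc1` gives 19.3 10^-6 cm/s in an ADME assay on MDCKII-LE cells (Canis lupus familiaris) for permeability; a lower number here means that the compound crosses the layer more slowly, a higher number that the compound crosses the layer faster. Compound 2 `N#CCCN([C@H](CCC(F)(F)F)C(N)=O)S(=O)(=O)c1ccc(Cl)cc1` gives 10.2 10^-6 cm/s; compound 3 `N#C[C@H]1C[C@H](CN([C@H](CCC(F)(F)F)C(N)=O)S(=O)(=O)c2ccc(Cl)cc2)C1` gives 24.9 10^-6 cm/s. Compound 2 stands lowest of the three numbers, with a 1.9-fold lower number from compound 1 to compound 2 (0.28 log units; within the scatter) and a 2.4-fold higher number from compound 2 to compound 3 (0.39 log units; beyond the scatter); between compound 1 and compound 3 the step is a 1.3-fold higher number from compound 1 to compound 3 (0.11 log units; within the scatter).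

Compound 4 `N#CC1(CN([C@H](CCC(F)(F)F)C(N)=O)S(=O)(=O)c2ccc(Cl)cc2)CC1` is not yet measured. It differs from compound 2 as follows: 1-cyanocyclopropyl in place of cyanomethyl on a saturated chain carbon bound to a sulfonamide nitrogen

The step that bears most directly on this one is a 2.4-fold higher number from compound 2 to compound 3 (0.39 log units; beyond the scatter), where a ring enters on the same saturated chain carbon bound to the sulfonamide nitrogen and the number rises modestly. The exchange toward compound 1, a 1.9-fold lower number from compound 1 to compound 2 (0.28 log units; within the scatter), stays within the scatter. A ring enters again from compound 2 to compound 4, though smaller than in compound 3, so a modest rise is expected for compound 4, with a 1.6-fold higher number from compound 2 to compound 4 (0.20 log units; within the scatter), and possibly none beyond the scatter. Compound 4 is therefore estimated at 16 10^-6 cm/s, ranging from 9 10^-6 cm/s to 28 10^-6 cm/s, pending the measurement.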

Compound 4, apparent permeability: 29.9 10^-6 cm/s
For compound 4 the middle estimate is 1.9-fold (0.27 log units) below the measured one; the measured number lies above the stated range.
By their numbers in this assay, from the lowest: compounds 2, 1, 3 and 4 (each within the scatter of the next, the first and the last beyond it).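

In this assay, a 2.9-fold higher number from compound 2 to compound 4 (0.47 log units; beyond the scatter) shows that a single three-membered ring of carbon, on a saturated chain carbon bound to a sulfonamide nitrogen, is enough to move the number beyond the scatter from cyanomethyl, so the rise does not require the four-membered ring of compound 3. The ring groups are not separated from one another, with a 1.2-fold higher number from compound 3 to compound 4 (0.08 log units; within the scatter) and a 1.5-fold higher number from compound 1 to compound 4 (0.19 log units; within the scatter), so this series gives no ranking among them. Nothing available explains the step from cyanomethyl.

From the compounds shown here alone, whether the nitrile on the ring matters for the number remains open, as does the effect of replacing it with an amine or a carboxylic acid. A longer chain carrying the nitrile, or a five-membered carbon ring in place of the three-membered one, would test how far this position tolerates change.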